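Para substituent swap on the benzylamide series

The source may hold more compounds than are shown below. What is called first, only, known or untested is meant among the compounds shown, and "the series" means these compounds.

Compound 1 `CC(C)[C@@H](N)C(=O)NCc1ccc(F)cc1` and compound 2 `COC[C@@H](N)C(=O)NCc1ccc(COc2cccc(F)c2)cc1` make up the measured set. In a functional assay on the whole organism (strain albino Sprague-Dawley) with Rattus norvegicus as the target, in the maximal electroshock model (on this read-out lower numbers stand for an effect already at smaller amounts and higher numbers for an effect only at larger amounts of compound), compound 1 gives 21 mg/kg; in this assay compound 2 gives 12 mg/kg, and the two numbers lie within the usual scatter of each other. Compound 3 `CC(C)[C@@H](N)C(=O)NCc1ccc(-c2ccccc2)cc1` is not yet measured. It differs from compound 1 by phenyl in place of fluoro on an aromatic carbon. Compound 2, which also carries a large group in place of a simple fluoro, gives 12 mg/kg, so such a group appears tolerated. The expected step is small, a 1.4-fold lower number from compound 1 to compound 3 (0.15 log units; within the scatter), not beyond the scatter. Compound 3 is estimated at 15 mg/kg, within 6 mg/kg to 40 mg/kg.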

Compound 3, dose for half-maximal effect: 30 mg/kg
Compound 3: middle estimate off by 2.0-fold (0.30 log units), on the low side, and the stated range covers the measured number.
By their numbers in this assay, from the lowest: compounds 2, 1 and 3 (each within the scatter of the next, the first and the last beyond it).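

Phenyl in place of fluoro on an aromatic carbon gives a 1.4-fold higher number from compound 1 to compound 3 (0.15 log units; within the scatter) in this assay, the only comparison shown that changes this position alone. With 6 heavy atoms and a six-membered aromatic ring entering where 1 heavy atom leaves, the step on the core of compound 1 stays within the scatter. Nothing at hand accounts for this step. Still open, on these data alone, is how an amine, a methoxy group or a carboxylic acid at this position would read, and whether phenyl gives a similar step on the core of compound 2.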